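A Methoxy Group on the Core of Compound 1

A few compounds are considered here, and "the series" means these few. Any claim that something is new, unique, unknown or untested is made for them only; others in the source may bear on it.

In a functional assay on HeLa cells (Homo sapiens) for cytotoxicity, read by MTT assay, with a stated time of 72 h (on this read-out lower numbers stand for stronger inhibition and higher numbers for weaker inhibition), compound 1 (`CCOC(=O)c1sc2ccccc2c1Nc1cc(OC)c(OC)c(OC)c1`) gives 3100 nM and compound 2 (`CCOC(=O)c1sc2cccc(C)c2c1Nc1cc(OC)c(OC)c(OC)c1`) gives 2520 nM, so the two lie within the scatter of each other. Compound 3 (`CCOC(=O)c1sc2cc(OC)ccc2c1Nc1cc(OC)c(OC)c(OC)c1`) differs from compound 1 by methoxy in place of hydrogen on an aromatic carbon. Within the data shown here, the only measured step that bears on this, methyl in place of hydrogen on an aromatic carbon, is a 1.2-fold lower number from compound 1 to compound 2 (0.09 log units; within the scatter). This single step involves a different group, so it offers weak guidance, and only a small shift towards a lower number is expected in this assay, not clearly beyond the scatter. The estimated step is a 1.7-fold lower number from compound 1 to compound 3 (0.24 log units; within the scatter). For compound 3 the expected value is 1800 nM, with an estimated range of 300 nM to 6000 nM.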

Compound 3, half-maximal inhibitory concentration: 0.56 nM
Beside the measured number, compound 3's estimate is 3200-fold (3.51 log units) above it, outside the stated range (below it).
By their numbers in this assay, from the lowest: compound 3; then compounds 2 and 1 (each within the scatter of the next).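

In this assay, methoxy in place of hydrogen on an aromatic carbon, meta to a fused ring and para to a fused ring, gives a 5500-fold lower number from compound 1 to compound 3 (3.74 log units; beyond the scatter), whereas the methyl step, a 1.2-fold lower number from compound 1 to compound 2 (0.09 log units; within the scatter), stays within the scatter. The shared core can therefore respond very strongly to a single small substituent, which the earlier pair did not reveal. No available evidence accounts for the size of this step. The compounds shown leave open whether this place requires methoxy specifically. On these data alone, whether a hydroxyl, an ethoxy or an amine there would give a similar number remains unknown.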